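Replacing the 1H-1,2,3-triazol-4-yl group with ethynyl

The source may report more compounds than this note shows. Statements on the series, on what has been measured and on what is new or still open speak of the compounds shown alone.

Of the compounds shown here, three have numbers so far in a physicochemical assay for solubility, read by turbidimetry, measured as kinetic solubility, at pH 6.8 (a lower number here means a less soluble compound, a higher number a more soluble compound), and they sit close together. Compound 1 (`COc1ccc(F)cc1N1C(=O)CSC1c1cccc(C(=O)NCCCCc2ccccc2)c1`) gives 10000 nM on this scale, compound 2 (`C#Cc1cc(C(=O)NCCCCc2ccccc2)cc(C2SCC(=O)N2c2ccccc2OC)c1`) gives 10000 nM on the same scale and compound 3 (`O=C(NCCCCc1ccccc1)c1cccc(C2SCC(=O)N2c2cccc(-c3c[nH]nn3)c2)c1`) gives 20000 nM as its reading. Compound 3 therefore stands within the scatter of both other compounds, and no order can be read among the three.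

The next structure is compound 4 (`C#Cc1cccc(N2C(=O)CSC2c2cccc(C(=O)NCCCCc3ccccc3)c2)c1`), which differs from compound 3 at a single group. ethynyl in place of 1H-1,2,3-triazol-4-yl on an aromatic carbon is the count for that change, ethynyl in place of 1H-1,2,3-triazol-4-yl on an aromatic carbon.

For the measured compounds named here, no measured pair isolates this exchange. The nearest evidence is the exchange of the whole group on the amide-type nitrogen in a ring, which gave a 2.0-fold higher number from compound 1 to compound 3 (0.30 log units; within the scatter) and so stayed within the scatter. Compound 2 also carries an ethynyl group, at another place in the molecule, and its reading of 10000 nM lies within the scatter of the other two.

The estimated step is a 2.0-fold lower number from compound 3 to compound 4 (0.30 log units; within the scatter) and no change beyond the scatter is expected in this assay on this evidence. Compound 4 is estimated at 10000 nM with 4000 nM to 20000 nM as the expected range.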

Compound 4, solubility: 10000 nM
For compound 4 middle estimate and measured number coincide at the digits printed, and the stated range covers the measured number.
By their numbers in this assay, from the lowest: compounds 1, 2, 4 and 3 (each within the scatter of the next).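

In this assay, for the compounds shown here, ethynyl in place of 1H-1,2,3-triazol-4-yl on an aromatic carbon of a six-membered aromatic ring of carbon only gives a 2.0-fold lower number from compound 3 to compound 4 (0.30 log units; within the scatter) and this is the first pair that isolates this exchange. The five-membered aromatic ring with 3 hetero atoms, with its hydrogen-bond donor and acceptors, thus leaves this position without a step beyond the scatter, even though the entering group has no ring, no hydrogen-bond donor and no hydrogen-bond acceptor. The whole group on the amide-type nitrogen in a ring can also now be compared with an ethynyl-bearing one: 3-ethynylphenyl in place of 5-fluoro-2-methoxyphenyl gives no change at the digits printed from compound 1 to compound 4 (within the scatter) and so this exchange too stays within the scatter.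

No accompanying measurement bears on what lies behind these readings.

From the compounds shown here alone, whether an amine or a carboxylic acid on this aromatic carbon would give a step beyond the scatter remains open. Going by these compounds, all four compounds also keep the same chain on the amide, so whether a shorter chain or one ending in an amine would shift the readings in this assay remains open as well.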